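Trimming a urea side chain to a small amide

This account rests on a few compounds, and the source may have more. Where it says the series, first, only, none or still open, it means among the compounds named here.

Compound 2 `CCNC(=O)NC[C@H]1CN(c2ccc(-n3cc(-c4ccccn4)cn3)c(F)c2)C(=O)O1` carries a ((ethylcarbamoyl)amino)methyl group on its saturated ring carbon. Among the measured compounds shown here, in a physicochemical assay for lipophilicity, read by HPLC, measured as octanol-water partition (on this read-out lower numbers stand for lower lipophilicity and higher numbers for higher lipophilicity), compound 2 gives 2.45, the higher of the two numbers measured so far. For the measured compounds named here, its only neighbour is compound 1 `CN1CCN(C[C@H]2CN(c3ccc(-n4cc(-c5ccccn5)cn4)c(F)c3)C(=O)O2)CC1`, which in this assay gives 2.2; the one measured step, a number 0.25 log units higher from compound 1 to compound 2 (within the scatter), stays within the scatter. Compound 3 `CNC(=O)[C@H]1CN(c2ccc(-n3cc(-c4ccccn4)cn3)c(F)c2)C(=O)O1` is not yet measured; the change from compound 2 to compound 3 is methylcarbamoyl in place of ((ethylcarbamoyl)amino)methyl on a saturated ring carbon. Going by the values given here, no measured step matches this change, and the step from compound 1 to compound 2 swapped a quite different group, so it offers only loose guidance. The side chain shrinks and a hydrogen-bond donor is lost. A small dip that stays within the scatter is expected. Compound 3 is therefore estimated at 2.15, with a range from 1.65 to 2.65, a step of a number 0.30 log units lower from compound 2 to compound 3 (within the scatter).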

Compound 3, partition coefficient: 1.39
Compound 3: middle estimate off by 0.76 log units, on the high side; the measured number lies below the stated range.
By their numbers in this assay, from the lowest: compound 3; then compounds 1 and 2 (each within the scatter of the next).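

The first step suggested that two very different side chains on this saturated ring carbon could leave the number in this assay nearly unchanged, yet methylcarbamoyl gives a number 1.06 log units lower from compound 2 to compound 3 (beyond the scatter) and also a number 0.81 log units lower from compound 1 to compound 3 (beyond the scatter). Both new steps lie beyond the scatter, so the group at this position can move this read-out after all, and compound 3 stands apart from the other two. The change from compound 2 to compound 3 shortens the side chain and removes a hydrogen-bond donor together, and nothing measured here explains the lower number.

The compounds shown cannot separate the effect of chain length from that of the amide group itself. An ethylcarbamoyl group on this ring carbon, a methylcarbamoyl group on a longer chain, or a simple amine or carboxylic acid there would each test a different part of this change.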